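The source may report more compounds than this note shows. Statements on the series, on what has been measured and on what is new or still open speak of the compounds shown alone.

Compound 1 `CN(C[C@H]1Cc2c(cccc2N2CCN(Cc3ccccn3)CC2)CN1)[C@H]1CCCc2cccnc21`: 40.4%
Compound 2 `CN(C[C@@H]1Cc2c(cccc2N2CCNCC2)CN1)[C@H]1CCCc2cccnc21`: 54.6%
Compound 3 `CN1CCN(c2cccc3c2C[C@H](CN(C)[C@H]2CCCc4cccnc42)N(C)C3)CC1`: 41.7%

In an ADME assay on microsomes from liver (Mus musculus) for metabolic stability, read by LC-MS, with a stated time of 10 min (a lower number here means that less of the compound is left, a higher number that more of the compound is left), compound 1 gives the lowest of the three numbers. Compound 3 sits within the scatter of compound 1, so no order can be read between those two, while compound 2 stands beyond the scatter above compound 1. Compound 4 `CN(C[C@H]1Cc2c(cccc2N2CCN(c3cccc(C(F)(F)F)c3)CC2)CN1)[C@H]1CCCc2cccnc21` is built from compound 1 by one change, (3-(trifluoromethyl)phenyl in place of (pyridin-2-yl)methyl on an amine nitrogen in a ring). For the measured compounds named here, no step between two measured compounds that differ in a single place is at hand, so nothing measured speaks directly to this change. The step of a number 7.4 percentage points lower from compound 1 to compound 4 (within the scatter) is expected to be small and downward, at most a little beyond the scatter. Compound 4 is therefore estimated at 33%, with a range from 15% to 50%.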

Compound 4, percent of the compound remaining: 72.3%
Compound 4: middle estimate off by 39.3 percentage points, on the low side; the whole stated range lies below it.
By their numbers in this assay, from the lowest: compounds 1 and 3 (each within the scatter of the next); then compound 2; then compound 4.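

In this assay, replacing (pyridin-2-yl)methyl with 3-(trifluoromethyl)phenyl on this amine nitrogen in a ring gives a large step, a number 31.9 percentage points higher from compound 1 to compound 4 (beyond the scatter). This is the first single-place comparison shown, and it establishes that the group at this position can move the read-out beyond the scatter. Nothing measured here accounts for the step.

The change replaces the whole group, so the compounds shown leave open which part of it carries the step. A plain phenyl or a benzyl group on the same nitrogen would separate these contributions.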